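Benzyl to 4-chlorophenyl on an aromatic nitrogen, two cores

This account rests on a few compounds, and the source may have more. Where it says the series, first, only, none or still open, it means among the compounds named here.

In a functional assay on HepG2 cells (Homo sapiens) for antiproliferative activity, read by MTT assay, with a stated time of 72 h (a higher number here means a weaker inhibitor, a lower number a stronger inhibitor), compound 1 `O=c1nc2oc(C3CC3)c(C#CC3CC3)c2cn1Cc1cn(Cc2ccccc2)nn1` gives 2670 nM. Compound 3 `CCCCCCC#Cc1c(CCCCCC)oc2nc(=O)n(Cc3cn(Cc4ccccc4)nn3)cc12` gives 25800 nM in this assay. The difference between the two cores is not broken down here. Compound 2 `CCCCCCC#Cc1c(CCCCCC)oc2nc(=O)n(Cc3cn(-c4ccc(Cl)cc4)nn3)cc12` returns only a limit in this assay, > 100000 nM. The change 4-chlorophenyl in place of benzyl on an aromatic nitrogen therefore produces an at least 3.8-fold higher number from compound 3 to compound 2 (0.58 log units; beyond the scatter), its true size open because of the limit of > 100000 nM in this assay, at which 1 of the 3 values shown sits. Compound 4 `O=c1nc2oc(C3CC3)c(C#CC3CC3)c2cn1Cc1cn(-c2ccc(Cl)cc2)nn1` carries the same change on the core of compound 1, (4-chlorophenyl in place of benzyl on an aromatic nitrogen), with the place described in the same words. Compound 4 is expected to be the weaker inhibitor, by an estimated 4.9-fold higher number from compound 1 to compound 4 (0.69 log units; beyond the scatter), resting on an at least 3.8-fold higher number from compound 3 to compound 2 (0.58 log units; beyond the scatter). The estimate for compound 4 in this assay is 13000 nM, likely between 4000 nM and 50000 nM.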

Compound 4, half-maximal inhibitory concentration: 39200 nM
Compound 4: the middle estimate sits 3.0-fold (0.48 log units) below what was measured, and the stated range covers the measured number.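

In this assay the change to 4-chlorophenyl in place of benzyl on an aromatic nitrogen weakens both pairs shown, and on the core of compound 1 it gives a 15-fold higher number from compound 1 to compound 4 (1.17 log units; beyond the scatter). The direction therefore carries from one core to the other in these two pairs, but a shared size is not shown: the same change on two cores in this assay, an at least 3.8-fold higher number (0.58 log units; beyond the scatter) from compound 3 to compound 2 and a 15-fold higher number (1.17 log units; beyond the scatter) from compound 1 to compound 4; the limit leaves it open whether they differ. Compound 2 gives only a limit, not a number: the limit of > 100000 nM in this assay, at which 1 of the 4 values shown sits.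

Plain phenyl and 4-chlorobenzyl on the same nitrogen are absent from the compounds shown, so the loss of the connecting carbon and the entry of chlorine cannot be told apart. On these data alone, whether the direction holds on a core bearing an amine or a carboxylic acid also remains open.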